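Pentyl-on-selenium analogues in a cytotoxicity series

A few compounds are considered here, and "the series" means these few. Any claim that something is new, unique, unknown or untested is made for them only; others in the source may bear on it.

Measured so far in a functional assay on MCF7 cells (Homo sapiens) for cytotoxicity, read by MTT assay, with a stated time of 72 h; a lower number here means that less compound is tolerated, a higher number that more compound is tolerated:

Compound 1, `CCCCC[Se]c1nc(NCc2ccc(SC)cc2)c2ccccc2n1`: compound 1 gives 95300 nM.
Compound 2, `CSc1ccc(CNc2nc([SeH])nc3ccccc23)cc1`: compound 2 reaches only a limit of the assay, > 100000 nM.
Compound 3, `Nc1nc([SeH])nc2ncccc12`: compound 3 likewise stops at a limit of the assay, > 100000 nM.

Two of the three values sit at the same ceiling, namely (the limit of > 100000 nM in this assay, at which 2 of the 3 values shown sit), so the series as it stands is nearly flat. Among the compounds with values here, the one measured step, from compound 2 to compound 1, is an at least 1.0-fold lower number from compound 2 to compound 1 (0.02 log units; that floor lies within the scatter), and the change behind it is pentyl in place of hydrogen on a selenium. Both structures around the selenium are described in the same words, so the change from compound 3 to compound 4 is the same change: compound 4, `CCCCC[Se]c1nc(N)c2cccnc2n1`, is not yet measured, and its difference from compound 3 is pentyl in place of hydrogen on a selenium. How the core of compound 3 differs from the core of compound 2 is not broken down here.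

For compound 4 in this assay the expected step from its parent is a number no higher from compound 3 to compound 4 (the limit leaves the size open), resting on the measured step of an at least 1.0-fold lower number from compound 2 to compound 1 (0.02 log units; that floor lies within the scatter), which stayed within scatter and left compound 1 near the ceiling. Compound 4 is therefore estimated at 100000 nM, with a range from 50000 nM to 300000 nM, and it is expected that the assay may again report only a limit rather than a number for compound 4.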

Compound 4, concentration lethal to 50% of the cells: 85000 nM
Compound 4: the middle estimate sits 1.2-fold (0.07 log units) above what was measured, within the range that was stated.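

In this assay, pentyl in place of hydrogen on a selenium gives an at least 1.1-fold lower number from compound 3 to compound 4 (0.07 log units; that floor lies within the scatter). The change has now been read on two cores, and the two readings stand side by side: the same change on two cores in this assay, an at least 1.0-fold lower number (0.02 log units; that floor lies within the scatter) from compound 2 to compound 1 and an at least 1.1-fold lower number (0.07 log units; that floor lies within the scatter) from compound 3 to compound 4; the limit leaves it open whether they differ

In both pairs the pentyl compound gives a number where its parent gives only a limit, but no step is shown to lie beyond the scatter, so the notes support neither a real effect of pentyl nor a size that carries from one core to the other: the limit of > 100000 nM in this assay, at which 2 of the 4 values shown sit.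

Still open, going by these compounds, is whether a shorter chain such as ethyl, a longer chain such as octyl or a benzyl on the selenium would bring either core clearly away from that ceiling. Also open, on these data alone, is whether any group on the selenium gives a step on these cores that can be read beyond the scatter and compared in size between them.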